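Isopropyl in place of benzyl on compound 1

The source may hold more compounds than are shown below. What is called first, only, known or untested is meant among the compounds shown, and "the series" means these compounds.

In an ADME assay on cells (Homo sapiens) for cytotoxicity (a lower number here means that less compound is tolerated, a higher number that more compound is tolerated), compound 1 `O=C1N(CCC(CCOc2ccc(-c3ccc(Cl)cc3)cc2)Cc2ccccc2)CCN1c1ccncc1` gives > 10000 nM as a limit and no number. Compound 2 `CC(CCCN1CCN(c2ccncc2)C1=O)COc1ccc(-c2ccc(Cl)cc2)cc1` likewise gives > 25000 nM as a limit and no number. Compound 3 `CC(C)C(CCOc1ccc(-c2ccc(Cl)cc2)cc1)CCN1CCN(c2ccncc2)C1=O` carries isopropyl in place of benzyl on a saturated chain carbon bound to two saturated chain carbons. Among the measured compounds shown here, no measured step tests this change, so only a small move towards more compound tolerated is expected in this assay and the expected size is a step that the limit leaves unreadable from compound 1 to compound 3 for now. For compound 3 the estimate is 20000 nM with an expected range from 8000 nM to 50000 nM in this assay.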

Compound 3, half-maximal cytotoxic concentration: > 25000 nM
Compound 3 was reported as a limit; the forecaster's own chance of this, stated with the estimate: 75%; at least 1.2-fold (0.09 log units) between middle value and limit.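

Compound 1 and compound 3 both stand as limits in this assay, so the change from benzyl to isopropyl gives no readable step. The compounds shown leave open where the half-maximal cytotoxic concentration of any of them actually lies.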